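Cyanophenyl regioisomer of a triazole-linked cinnamic acid

The source may report more compounds than this note shows. Statements on the series, on what has been measured and on what is new or still open speak of the compounds shown alone.

The series shares one core, seen in compound 1 `COc1ccc(/C=C\C(=O)O)c(OCc2cn(-c3cccc(C#N)c3)nn2)c1CC=C(C)C`, which in a functional assay on T47D cells (Homo sapiens) for cytotoxicity, read by MTT assay, with a stated time of 24 h (on this read-out higher numbers stand for weaker inhibition and lower numbers for stronger inhibition), gives 19200 nM. Compound 2 `COc1ccc(/C=C\C(=O)O)c(OCc2cn(-c3cccnc3Cl)nn2)c1CC=C(C)C` carries a 2-chloropyridin-3-yl group on the aromatic nitrogen of the triazole; in this assay compound 2 is recorded as "not determined" (no result reported), so no number stands for it on the table.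

The step from compound 2 leads to compound 3 `COc1ccc(/C=C\C(=O)O)c(OCc2cn(-c3ccccc3C#N)nn2)c1CC=C(C)C`, with the change (2-cyanophenyl in place of 2-chloropyridin-3-yl on an aromatic nitrogen), that is, 2-cyanophenyl in place of 2-chloropyridin-3-yl on an aromatic nitrogen. Among the compounds with values here, no measured step between these two compounds exists, and the size of the change in this assay can only be guessed. Compound 1, the closest measured relative, gives 19200 nM in this assay and offers the only anchor.

Compound 3 is therefore expected to show about 19000 nM, within a range of 6000 nM to 60000 nM.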

Compound 3, half-maximal inhibitory concentration: 8800 nM
Beside the measured number, compound 3's estimate is 2.2-fold (0.33 log units) above it; the measured number falls inside the stated range.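

In this assay, the place of the nitrile on the phenyl ring matters at this position: 2-cyanophenyl in place of 3-cyanophenyl on an aromatic nitrogen gives a 2.2-fold lower number from compound 1 to compound 3 (0.34 log units; beyond the scatter), a modest step with the rest of the core unchanged. Compound 2 has no reported result, so its step to compound 3 cannot be read, and the 2-chloropyridin-3-yl group cannot be ranked against either nitrile-bearing group. No supporting data account for the shift between the two cyanophenyl groups.

On these data alone, it remains open whether the nitrile itself contributes, as a plain phenyl group on the same nitrogen would show. Also open, as far as these compounds go, is how an amine or a carboxylic acid would compare with the nitrile at the same place on the ring in this assay.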